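A few compounds are considered here, and "the series" means these few. Any claim that something is new, unique, unknown or untested is made for them only; others in the source may bear on it.

In a functional assay on HGC-27 cells (Homo sapiens) for inhibition, read by MTT assay, with a stated time of 72 h (a higher number here means a weaker inhibitor, a lower number a stronger inhibitor), compound 1 `Cc1cc(N2CC[C@@H](C)[C@@H](N(C)c3ncnc4[nH]ccc34)C2)n2nc(SCc3nc4ccccc4[nH]3)nc2n1` gives > 100000 nM as a limit of the assay, not a number. In this assay, for the measured compounds named here, compound 2 `Cc1cc(N2CC[C@@H](C)[C@@H](N(C)c3ncnc4[nH]ccc34)C2)n2nc(SCCc3ccccc3)nc2n1` stands at 11800 nM and holds the only actual number so far. Compound 3 `Cc1ccc(CSc2nc3nc(C)cc(N4CC[C@@H](C)[C@@H](N(C)c5ncnc6[nH]ccc56)C4)n3n2)cc1` has the same atoms as compound 2, joined differently: 4-methylphenyl in place of benzyl on a saturated chain carbon bound to a sulfur and in words this is 4-methylphenyl in place of benzyl on a saturated chain carbon bound to a sulfur. Going by the values given here, the one measured step at that place is an at least 8.4-fold lower number from compound 1 to compound 2 (0.92 log units; beyond the scatter) and it shows that a swap there can matter, yet it involves a different group and rests on a limit. The expectation therefore stays anchored on compound 2 at 11800 nM and favours no direction. The estimated change is a 1.2-fold lower number from compound 2 to compound 3 (0.07 log units; within the scatter) and is expected to stay within the scatter. For compound 3 the expected value is 10000 nM within an estimated range from 3500 nM to 30000 nM in this assay.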

Compound 3, half-maximal inhibitory concentration: 15200 nM
Compound 3: middle estimate off by 1.5-fold (0.18 log units), on the low side, and the stated range covers the measured number.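

In this assay, 4-methylphenyl in place of benzyl on a saturated chain carbon bound to a sulfur gives a 1.3-fold higher number from compound 2 to compound 3 (0.11 log units; within the scatter), so rearranging the same carbons at this place does not measurably move the number. 4-Methylphenyl in place of 1H-benzimidazol-2-yl gives an at least 6.5-fold lower number from compound 1 to compound 3 (0.81 log units; beyond the scatter), which means that compound 3, like compound 2, lies clearly apart from compound 1. The value of compound 1 is a limit of the assay, not a number: the limit of > 100000 nM in this assay, at which 1 of the 3 values shown sits.

Compound 3 has a shorter chain and an added methyl compared with compound 2, so a plain benzyl on the sulfur would be needed to tell whether these two changes each do nothing or offset each other. Also open, on these data alone, is whether an amine or a carboxylic acid on the aromatic ring, or a longer chain, would lower the number.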